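Series notes: furan-2-yl replacing thiophen-3-yl on the core

The source may report more compounds than this note shows. Statements on the series, on what has been measured and on what is new or still open speak of the compounds shown alone.

Of the compounds shown here, three of the shared core have been measured in a functional assay on DU-145 cells (Homo sapiens) for cytotoxicity, read by CCK-8 assay and cell counting, with a stated time of 2 days; on this read-out higher numbers stand for weaker inhibition and lower numbers for stronger inhibition. Compound 1 `Oc1ccc(-c2cc(-c3ccc(Cl)cc3)nc(-c3ccsc3)c2)cc1` gives 6940 nM; compound 2 `Oc1cccc(-c2cc(-c3ccc(Cl)cc3)nc(-c3ccsc3)c2)c1` gives 11600 nM; compound 3 `Oc1ccc(-c2cc(-c3ccsc3)nc(-c3cccc(Cl)c3)c2)cc1` gives 6220 nM. Compound 1 stands second highest of the three numbers, with compound 3 nearest and compound 2 furthest, and both of those gaps lie within the scatter: a 1.1-fold lower number from compound 1 to compound 3 (0.05 log units; within the scatter) and a 1.7-fold higher number from compound 1 to compound 2 (0.22 log units; within the scatter).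

Compound 4 `Oc1ccc(-c2cc(-c3ccc(Cl)cc3)nc(-c3ccco3)c2)cc1` has not yet been measured. It differs from compound 1 in one place: furan-2-yl in place of thiophen-3-yl on an aromatic carbon. Neither measured step concerns this position; both concern the hydroxyphenyl and the chlorophenyl groups, and both stayed within the scatter. For the measured compounds named here, there is thus no direct precedent for exchanging the five-membered ring, and the only guide is that the core has so far tolerated single changes on its aromatic substituents without a step beyond the scatter.

The expectation for compound 4 in this assay is therefore a number close to that of compound 1, with a step of a 1.1-fold higher number from compound 1 to compound 4 (0.03 log units; within the scatter) not beyond the scatter. Compound 4 is estimated at 7500 nM, within a range from 2500 nM to 22000 nM, the wide range reflecting the absence of any measured step for this change.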

Compound 4, half-maximal inhibitory concentration: 7280 nM
Compound 4: the middle estimate sits 1.0-fold (0.01 log units) above what was measured; measured number inside the range.
By their numbers in this assay, from the lowest: compounds 3, 1, 4 and 2 (each within the scatter of the next).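

In this assay, for the compounds shown here, the first reading at the position next to the ring nitrogen is a 1.0-fold higher number from compound 1 to compound 4 (0.02 log units; within the scatter). The exchange replaces sulfur with oxygen in the five-membered ring and moves the point of attachment from the 3-yl to the 2-yl position, and neither change together takes the number beyond the scatter. Single changes at all three aryl positions of compound 1 now stay within the scatter, with no shown compound going against this, although no available evidence bears on the reason for this result.

The two groups compared here are both five-membered aromatic rings with one hetero atom, so the compounds shown leave open whether the position would accept something of a different kind, such as a piperidine, a carboxylic acid or a butyl chain. Also open is whether furan-2-yl would read the same alongside the 3-hydroxyphenyl or 3-chlorophenyl groups, since the shown changes have each been read only singly against compound 1.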